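A few compounds are considered here, and "the series" means these few. Any claim that something is new, unique, unknown or untested is made for them only; others in the source may bear on it.

Three compounds have been measured in a functional assay on HL-60 cells (Homo sapiens) for inhibition, read by MTT assay, with a stated time of 48 h; a lower number here means a stronger inhibitor, a higher number a weaker inhibitor:

Compound 1 `O=C(/C=C/c1cccc([N+](=O)[O-])c1)c1ccc[nH]1` gives 20000 nM in this assay.
Compound 2 `COc1cccc(/C=C/C(=O)c2ccc[nH]2)c1` gives 16000 nM in this assay.
Compound 3 `O=C(/C=C/c1ccccc1Cl)c1ccco1` gives 12000 nM in this assay.

Compound 3 has the lowest of these three numbers, but its gaps to compound 2 and to compound 1 both lie within the usual scatter of repeated measurements, so none of the three can be called stronger or weaker than another. Compound 4 `O=C(/C=C/c1cc([N+](=O)[O-])ccc1Cl)c1ccco1` has not yet been measured. It differs from compound 3 in one place: nitro in place of hydrogen on an aromatic carbon. For the measured compounds named here, only one measured step concerns a change of a group on the same kind of ring, namely a 1.3-fold lower number from compound 1 to compound 2 (0.10 log units; within the scatter), and that pair swaps one group for another on a core unlike the core of compound 3. Going by the values given here, no measured pair shows a hydrogen giving way to a nitro group. Among the compounds with values here, the expectation therefore rests on the single measured change on that ring having stayed within the scatter, and compound 4 is expected to show no change at the digits printed from compound 3 to compound 4 (within the scatter), that is, no step beyond the scatter. The estimate for compound 4 in this assay is 12000 nM, with a range from 5000 nM to 30000 nM.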

Compound 4, half-maximal inhibitory concentration: 58000 nM
Beside the measured number, compound 4's estimate is 4.8-fold (0.68 log units) below it; the whole stated range lies below it.
By their numbers in this assay, from the lowest: compounds 3, 2 and 1 (each within the scatter of the next); then compound 4.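

In this assay, placing a nitro group on the aromatic carbon para to the chloro group turns compound 3 into a weaker inhibitor (a 4.8-fold higher number from compound 3 to compound 4 (0.68 log units; beyond the scatter)). This shows that the ring of compound 3 is sensitive to a change at this position, with a step large enough to stand clear of the scatter. For the compounds shown here, the only earlier step (a 1.3-fold lower number from compound 1 to compound 2 (0.10 log units; within the scatter)) stayed within the scatter, and it swapped one group for another on a different core, so it could not reveal this; no available evidence accounts for the weakening.

On these data alone, it remains open whether the weakening belongs to the nitro group itself or would follow any addition at this carbon. An amine or a carboxylic acid at the same place would help separate those two readings.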